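Diarylurea series: chloro in place of trifluoromethyl

The compounds below may be only part of what the source reports. "The series", "measured", "known", "first", "only" and "open" are said of these compounds alone.

compound 1 `COc1cc(Cl)cc(-c2nn(-c3cccc(NC(=O)c4ccc(Cl)c(Cl)c4)c3)cc2-c2ccncc2)c1`: 34%
compound 2 `O=C(Nc1cccc(-n2cc(-c3ccncc3)c(-c3cc(O)cc(Cl)c3)n2)c1)Nc1ccc(Cl)c(C(F)(F)F)c1`: 5.34%

In a functional assay on PC-3 cells (Homo sapiens) for inhibition, read by sulforhodamine B assay, with a stated time of 48 h, tested at 10 uM (a lower number here means a stronger effect, a higher number a weaker effect of the compound at the concentration tested), compound 1 gives 34%, and compound 2 gives 5.34%. Compound 2 stands lowest of the two numbers; its nearest neighbour is compound 1, whose number lies higher by a gap beyond the scatter. Compound 3 `O=C(Nc1cccc(-n2cc(-c3ccncc3)c(-c3cc(O)cc(Cl)c3)n2)c1)Nc1ccc(Cl)c(Cl)c1` has not been measured yet; it differs from compound 2 by chloro in place of trifluoromethyl on an aromatic carbon. Among the compounds with values here, no pair of measured compounds shows this change, so no measured step guides it. The step from compound 2 to compound 3 is expected to be small, a number 4.7 percentage points higher from compound 2 to compound 3 (within the scatter), not beyond the scatter in either direction. Compound 3 is therefore estimated at 10%, within a range of 2% to 28%.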

Compound 3, a percentage reported as activity, at one concentration (the size of the read-out at that concentration, not a potency): -1.66%
Estimate against measurement, compound 3: 11.7 percentage points above; measured number outside the range, below it.
By their numbers in this assay, from the lowest: compounds 3 and 2 (each within the scatter of the next); then compound 1.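

In this assay, within the data shown here, going from 4-chloro-3-(trifluoromethyl)phenyl to 3,4-dichlorophenyl gives a number 7 percentage points lower from compound 2 to compound 3 (within the scatter), the first measured reading of chloro in place of trifluoromethyl at this position. On this urea-linked ring, one chlorine atom therefore holds the read-out at the level seen with the four-atom trifluoromethyl group, at this single concentration. Nothing measured bears on why the two groups read alike.

As far as these compounds go, whether a nitrile or an amine at this position would hold the read-out in the same way remains open. A single-concentration read-out also leaves open whether compound 2 and compound 3 would match in the size of their effect at any other concentration.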